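Urea series on a shared core: the step to compound 4

The compounds below may be only part of what the source reports. "The series", "measured", "known", "first", "only" and "open" are said of these compounds alone.

Measured in a functional assay on HepG2 cells (Homo sapiens) for antiproliferative activity, read by MTT assay, with a stated time of 48 h; a higher number here means a weaker inhibitor, a lower number a stronger inhibitor:
- compound 1 `Cc1ccc(NC(=O)Nc2cccc(CNc3nccnc3Cl)c2)cc1C`: 10700 nM
- compound 2 `O=C(Nc1cccc(CNc2nccnc2Cl)c1)Nc1ccccc1Cl`: 8560 nM
- compound 3 `O=C(Nc1cccc(CNc2nccnc2Cl)c1)Nc1ccc(Cl)cc1Br`: 6720 nM

The three compounds share one core and differ only in the group on an amide-type nitrogen. Compound 3 has the lowest number of the three, but the steps to it are small: a 1.6-fold lower number from compound 1 to compound 3 (0.20 log units; within the scatter) and a 1.3-fold lower number from compound 2 to compound 3 (0.11 log units; within the scatter), and a 1.3-fold lower number from compound 1 to compound 2 (0.10 log units; within the scatter) is of the same kind. All three values sit within the scatter of one another, so no order among them can be read from these numbers.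

Compound 4 `O=C(Nc1cccc(CNc2nccnc2Cl)c1)NC1CCCC1` is the next member. Its change from compound 3 is cyclopentyl in place of 2-bromo-4-chlorophenyl on an amide-type nitrogen. Going by the values given here, none of the measured steps bears on this change: each of them swaps one six-membered aromatic ring of carbon only for another of the same kind, whereas here an aromatic ring leaves and a five-membered non-aromatic ring enters. The measured steps therefore give no direction for this assay beyond showing that the group on this nitrogen has so far moved the number little.

Among the compounds with values here, with no step of this kind on record, the expected step is a 1.3-fold higher number from compound 3 to compound 4 (0.13 log units; within the scatter), carrying a wide range. Compound 4 is estimated at 9000 nM, between 3500 nM and 25000 nM.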

Compound 4, half-maximal inhibitory concentration: 18400 nM
Compound 4: the middle estimate sits 2.0-fold (0.31 log units) below what was measured, within the range that was stated.
By their numbers in this assay, from the lowest: compounds 3, 2, 1 and 4 (each within the scatter of the next, the first and the last beyond it).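

In this assay, going by these compounds alone, the group on this amide-type nitrogen now gives steps beyond the scatter for the first time: cyclopentyl set against the two halogen-bearing phenyl groups gives modest steps (a 2.7-fold higher number from compound 3 to compound 4 (0.44 log units; beyond the scatter)) and (a 2.1-fold higher number from compound 2 to compound 4 (0.33 log units; beyond the scatter)). The 3,4-dimethylphenyl group of compound 1 goes against any claim that all the aromatic groups shown do better than cyclopentyl, since that step stays within the scatter (a 1.7-fold higher number from compound 1 to compound 4 (0.24 log units; within the scatter)), so the separation holds only for the 2-bromo-4-chlorophenyl and 2-chlorophenyl compounds. No measurement on hand bears on what lies behind this difference.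

Compound 4 changes ring size, aromatic character and halogen content in a single step, so these compounds cannot show which of them matters; a cyclohexyl group, an unsubstituted phenyl group or an open-chain butyl group on the same nitrogen would begin to pull them apart. Also open, on these data alone, are a ring carrying an amine or a carboxylic acid at this nitrogen, and any change to the shared core, which stays fixed throughout these four compounds.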